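From a Cyclopentyl to a Cyclohexyl Amine

The source may report more compounds than this note shows. Statements on the series, on what has been measured and on what is new or still open speak of the compounds shown alone.

Of the compounds shown here, three built on one shared core have been tested in a functional assay on MGC-803 cells (Homo sapiens) for inhibition, read by sulforhodamine B assay; a lower number here means a stronger inhibitor, a higher number a weaker inhibitor. Compound 1 `O=C1C(NC2CCCC2)=CC(=O)c2c1nc1n2[C@H]2OC[C@@H](O)[C@H]2OC1` carries a cyclopentyl group on an amine nitrogen. In this assay compound 1 gives > 16000 nM, and this is a limit of the assay rather than a measured number (the limit of > 16000 nM in this assay, at which 1 of the 3 values shown sits). Compound 2 `CCOc1ccccc1NC1=CC(=O)c2nc3n(c2C1=O)[C@H]1OC[C@@H](O)[C@H]1OC3` carries a 2-ethoxyphenyl group in that position and gives 2450 nM in this assay. Compound 3 `O=C1C=C(Nc2ccc(I)cc2)C(=O)c2c1nc1n2[C@H]2OC[C@@H](O)[C@H]2OC1` carries a 4-iodophenyl group and gives 1400 nM in this assay. Among the measured compounds shown here, the only single-point step among them is a 1.8-fold lower number from compound 2 to compound 3 (0.24 log units; within the scatter), a change that stays within the scatter.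

Compound 4 `O=C1C(NC2CCCCC2)=CC(=O)c2c1nc1n2[C@H]2OC[C@@H](O)[C@H]2OC1` differs from compound 1 by cyclohexyl in place of cyclopentyl on an amine nitrogen. For the measured compounds named here, no measured step exchanges one saturated ring for another, and the aryl-to-aryl step between compound 2 and compound 3 bears on this change only loosely. With compound 1 standing at a limit, no movement beyond the scatter is expected, and compound 4 may well sit at a limit again. Compound 4 is therefore estimated at about 16000 nM, with a range from 5000 nM to 50000 nM. The expected step is a number no higher from compound 1 to compound 4 (the limit leaves the size open).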

Compound 4, half-maximal inhibitory concentration: > 8000 nM
Compound 4: no number, only a limit; the forecaster's own chance of this, stated with the estimate: 65%; the middle value lies beyond the limit too.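

Compound 1 and compound 4 each stand at a limit of this assay rather than at a number, and the change from cyclopentyl to cyclohexyl therefore gives no readable step. On these data alone, how strongly either compound actually inhibits, and whether the two rings differ at all, remains open.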